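This account rests on a few compounds, and the source may have more. Where it says the series, first, only, none or still open, it means among the compounds named here.

Measured in a functional assay on T98G cells (Homo sapiens) for cytotoxicity, read by MTT assay, with a stated time of 48 h; a higher number here means a weaker inhibitor, a lower number a stronger inhibitor:
- compound 1 `C/C(=N/NC(=S)Nc1ccccc1F)c1ccccn1`: 3.1 nM
- compound 2 `C/C(=N/NC(=S)Nc1ccccc1I)c1ccccn1`: 8.09 nM

Compound 2, at 8.09 nM, holds the higher of the two numbers, which makes it the weaker inhibitor of this pair. The next compound, compound 3 `C/C(=N/NC(=S)Nc1ccccc1[N+](=O)[O-])c1ccccn1`, has nitro in place of iodo on an aromatic carbon, ortho to a large group (nitro in place of iodo on an aromatic carbon). For the measured compounds named here, only one measured step bears on this change: a 2.6-fold higher number from compound 1 to compound 2 (0.42 log units; beyond the scatter), where iodo replaced fluoro at that same kind of carbon. Going by the values given here, that step was modest, and no measured compound yet carries nitro, so the data give no direction for the new swap. In this assay, a step of similar modest size is the most that can reasonably be expected, and none beyond the scatter is the central expectation. The estimate corresponds to an expected 1.3-fold lower number from compound 2 to compound 3 (0.13 log units; within the scatter). For compound 3 the estimated value is 6 nM, with an expected range of 1.5 nM to 25 nM.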

Compound 3, half-maximal inhibitory concentration: 6.61 nM
Compound 3: middle estimate off by 1.1-fold (0.04 log units), on the low side; the measured number falls inside the stated range.
By their numbers in this assay, from the lowest: compound 1; then compounds 3 and 2 (each within the scatter of the next).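

In this assay, placing nitro where iodo stood on this aromatic carbon, ortho to a large group, gives a 1.2-fold lower number from compound 2 to compound 3 (0.09 log units; within the scatter), so these two groups cannot be told apart here, although nitro brings more heavy atoms and hydrogen-bond acceptors that iodo lacks. Fluoro now stands apart from both, with a 2.1-fold higher number from compound 1 to compound 3 (0.33 log units; beyond the scatter), which leaves compound 1 with the lowest number of the three, its steps to the other two both lying beyond the scatter. No measurement here explains why the numbers fall this way.

As far as these compounds go, it remains open whether a plain hydrogen, chloro, an amine or methoxy at this carbon would sit with compound 1 or with compounds 2 and 3. From the compounds shown here alone, it also remains open whether nitro and iodo would still match at another carbon of this ring.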